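This account rests on a few compounds, and the source may have more. Where it says the series, first, only, none or still open, it means among the compounds named here.

Measured so far in a physicochemical assay for acid dissociation:
compound 1 `C/C=C/COc1noc2c1CNCC2`: 7.7
compound 2 `COc1noc2c1CN(Cc1ccccc1)CC2`: 6
compound 3 `CCN1CCc2onc(OC)c2C1`: 7

Of these three, compound 1 stands highest at 7.7. Compound 3 at 7 and compound 2 at 6 both lie lower, beyond the scatter of this assay.

A further compound, compound 4 `CCCOc1noc2c1CNCC2`, is still to be measured. It departs from compound 1 in one place: ethyl in place of prop-1-en-1-yl on a saturated chain carbon bound to an oxygen on an aromatic ring. Ethyl takes the place of prop-1-en-1-yl on a saturated chain carbon bound to an oxygen on an aromatic ring, which can also be read as but-2-en-1-yl giving way to propyl.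

Among the measured compounds shown here, only one step between measured compounds is available, a number 1.00 log units higher from compound 2 to compound 3 (beyond the scatter). There, methyl replaces phenyl on a saturated chain carbon bound to an amine nitrogen in a ring, so that step lies at another place and involves a different pair of groups. For the measured compounds named here, no measured step covers a change on the chain at the oxygen, and none gives a size to carry over. The value of compound 1, 7.7, therefore remains the starting point, with a higher read-out no more expected than a lower one. The expected change is no change at the digits printed from compound 1 to compound 4 (within the scatter), which means no step beyond the scatter. Compound 4 is estimated at 7.7. The expected range for compound 4 runs from 7.3 to 8.1.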

Compound 4, acid dissociation constant: 7.6
Beside the measured number, compound 4's estimate is 0.10 log units above it; the measured number falls inside the stated range.
By their numbers in this assay, from the lowest: compound 2; then compound 3; then compounds 4 and 1 (each within the scatter of the next).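

In this assay, the chain on the oxygen now has its first measured step, and the exchange of prop-1-en-1-yl for ethyl reads a number 0.10 log units lower from compound 1 to compound 4 (within the scatter). Read with the longer names, but-2-en-1-yl gives way to propyl, so this pair loses one carbon and the double bond outside aromatic rings, yet the two compounds cannot be told apart in this assay, whereas the only earlier step, a number 1.00 log units higher from compound 2 to compound 3 (beyond the scatter), concerned a different place, on a saturated chain carbon bound to an amine nitrogen in a ring. Nothing available explains why this exchange leaves the two compounds within the scatter of each other.

This single pair says nothing yet about groups that differ more widely from these two, such as a hexyl chain, a benzyl group or a chain ending in a carboxylic acid at the same place on the oxygen. It also leaves open whether a group such as methyl or benzyl on the ring nitrogen of compound 4 would give a step of the size seen between the other compounds.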